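The source may hold more compounds than are shown below. What is called first, only, known or untested is meant among the compounds shown, and "the series" means these compounds.

Within the data shown here, in a functional assay on HCT-116 cells (Homo sapiens) for antiproliferative activity, read by MTT assay, with a stated time of 72 h (on this read-out higher numbers stand for weaker inhibition and lower numbers for stronger inhibition), compound 2 (`COc1ccc(NC(=O)CCc2cccc3c2B(O)OC3)cc1`) gives 1700 nM and holds the lower of the two numbers so far, while compound 1 (`C#Cc1ccc(NC(=O)CCc2cccc3c2B(O)OC3)cc1`) gives 45000 nM on the higher side. Compound 3 (`COc1ccc(NC(=O)CCc2cccc3c2B(O)OC3)cc1OC`) has methoxy in place of hydrogen on an aromatic carbon of compound 2 (methoxy in place of hydrogen on an aromatic carbon). Among the measured compounds shown here, the only measured step that bears on this is a 26-fold lower number from compound 1 to compound 2 (1.42 log units; beyond the scatter) and it was large, but it exchanged ethynyl for methoxy and added no second methoxy, so it says little here. No clear direction follows, and the expected change is a 1.1-fold lower number from compound 2 to compound 3 (0.05 log units; within the scatter) with no shift beyond the scatter foreseen. For compound 3 the estimate is 1500 nM as the expected value, within an expected range of 500 nM to 5000 nM for this measurement.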

Compound 3, half-maximal inhibitory concentration: > 100000 nM
Compound 3: a limit, no number; the forecaster's own chance of this, stated with the estimate: 3%; middle value at least 66-fold (1.82 log units) away from the limit.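

Compound 2 and compound 1 differed only in the group at one aromatic carbon, whereas this change adds a group at a new one, ortho to a methoxy group. One added methoxy there is far from harmless: in this assay the change gives an at least 58-fold higher number from compound 2 to compound 3 (1.76 log units; beyond the scatter). Compound 3 is recorded as a limit of the assay and not a number: the limit of > 100000 nM in this assay, at which 1 of the 3 values shown sits.

Going by these compounds, whether a fluorine, a hydroxyl or an amine at this same carbon would keep the activity of compound 2 remains open. So does whether a methoxy at another free ring carbon would cost as much.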